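The source may report more compounds than this note shows. Statements on the series, on what has been measured and on what is new or still open speak of the compounds shown alone.

Of the compounds shown here, three built on one shared core have been measured in a functional assay on cells (Melanoma cell, Homo sapiens) for cytotoxicity, read by sulforhodamine B assay, with a stated time of 48 h; a lower number here means a stronger inhibitor of growth, a higher number a weaker inhibitor of growth. Compound 1 `O=C1N=C(N2N=C(c3ccccc3)CC2c2ccccc2O)S/C1=C1/C(=O)Nc2ccccc21` gives 2040 nM. Compound 2 `COc1ccc(C2CC(c3ccccc3)=NN2C2=NC(=O)/C(=C3\C(=O)Nc4ccccc43)S2)cc1` gives 2000 nM, and compound 3 `COc1ccc(C2CC(c3ccccc3)=NN2C2=NC(=O)/C(=C3\C(=O)Nc4ccc(Br)cc43)S2)cc1` gives 210 nM. Among these three numbers compound 2 stands second highest: the step from compound 1 to compound 2 is a 1.0-fold lower number from compound 1 to compound 2 (0.01 log units; within the scatter), so those two cannot be told apart, while from compound 2 to compound 3 the number moved by a 9.5-fold lower number from compound 2 to compound 3 (0.98 log units; beyond the scatter).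

Compound 4 `COc1ccc(C2=NN(C3=NC(=O)/C(=C4\C(=O)Nc5ccccc54)S3)C(c3ccc(OC)cc3)C2)cc1` differs from compound 2 by methoxy in place of hydrogen on an aromatic carbon. Going by the values given here, the measured step that bears on this is the one from compound 1 to compound 2, where 4-methoxyphenyl replaced 2-hydroxyphenyl on a saturated ring carbon and the number changed by a 1.0-fold lower number from compound 1 to compound 2 (0.01 log units; within the scatter), within the scatter. The bromo step from compound 2 to compound 3 concerns a different ring and does not speak to this change. For compound 4 a step within the scatter is therefore expected, no change at the digits printed from compound 2 to compound 4 (within the scatter). In this assay compound 4 is estimated at 2000 nM, with a range from 900 nM to 4500 nM.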

Compound 4, concentration for 50% growth inhibition: 100000 nM
Compound 4: the middle estimate sits 50-fold (1.70 log units) below what was measured; measured number above the stated range.
By their numbers in this assay, from the lowest: compound 3; then compounds 2 and 1 (each within the scatter of the next); then compound 4.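

In this assay, the change from phenyl to 4-methoxyphenyl gives a 50-fold higher number from compound 2 to compound 4 (1.70 log units; beyond the scatter), so this ring, plain phenyl in all three earlier compounds, is not indifferent to what it carries: here a single methoxy group nearly abolishes growth inhibition over the range tested so far. The earlier change on the saturated ring carbon gave a 1.0-fold lower number from compound 1 to compound 2 (0.01 log units; within the scatter), so a 4-methoxyphenyl group at that place went with no visible loss, and the outcome depends on where the group stands. Nothing available here explains the loss at this ring.

The compounds shown leave open whether any group at this spot weakens growth inhibition or only methoxy does; a fluoro, a hydroxyl or an amine there would help to tell. From the compounds shown here alone, it also remains open whether adding the bromo of compound 3 would recover any activity in compound 4.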